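Removing one methoxy group from compound 1

The compounds below may be only part of what the source reports. "The series", "measured", "known", "first", "only" and "open" are said of these compounds alone.

Compound 1 `COc1cc(NS(=O)(=O)c2ccc(N3CCNC3=O)cc2)cc(OC)c1OC` gives 19 nM
Compound 2 `O=C1NCCN1c1ccc(S(=O)(=O)Nc2cccc(Br)c2)cc1` gives 87 nM
Compound 3 `Cc1cc(C)cc(NS(=O)(=O)c2ccc(N3CCNC3=O)cc2)c1` gives 110 nM

These values come from a functional assay on K562 cells (Homo sapiens) for antiproliferative activity, read by sulforhodamine B assay, with a stated time of 48 h (on this read-out higher numbers stand for weaker inhibition and lower numbers for stronger inhibition), and compound 1 has the lowest of the three, clearly apart from the other two. Compound 4 `COc1cc(NS(=O)(=O)c2ccc(N3CCNC3=O)cc2)cc(OC)c1` has not been measured. Among the measured compounds shown here, the change from compound 1 is hydrogen in place of methoxy on an aromatic carbon and no measured step tests it directly. The nearest evidence is a 1.3-fold higher number from compound 2 to compound 3 (0.10 log units; within the scatter) which stays within the scatter. Compound 1 alone carries methoxy groups, while compound 2 (87 nM) and compound 3 (110 nM) lie higher. A higher number is therefore expected, and a step of a 3.7-fold higher number from compound 1 to compound 4 (0.57 log units; beyond the scatter) is the estimate. For compound 4 the estimated value is 70 nM with an expected range from 25 nM to 200 nM on this read-out.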

Compound 4, half-maximal inhibitory concentration: 110 nM
For compound 4 the middle estimate is 1.6-fold (0.20 log units) below the measured one; low and high end bracket the measured number.
By their numbers in this assay, from the lowest: compound 1; then compounds 2, 3 and 4 (each within the scatter of the next).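

Among the compounds shown here, putting hydrogen in place of the methoxy group that is ortho to two methoxy groups gives a 5.8-fold higher number from compound 1 to compound 4 (0.76 log units; beyond the scatter) and so tests this position directly for the first time. The two remaining methoxy groups do not hold the number at the level of compound 1, so this single group counts on its own. Nothing measured here explains the step.

As far as these compounds go, whether an amine, a hydroxyl group or a fluorine at this position would keep the number low stays open. So does the result of removing either of the other two methoxy groups.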